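Cytotoxicity notes on the step to compound 3

A few compounds are considered here, and "the series" means these few. Any claim that something is new, unique, unknown or untested is made for them only; others in the source may bear on it.

Measured so far in an ADME assay on BHK-21 cells (Mesocricetus auratus) for cytotoxicity, read by MTT assay (on this read-out higher numbers stand for lower toxicity in this test and lower numbers for higher toxicity in this test), with these results:
- Compound 1 `CC(=O)c1ccc2c(c1)nc(-c1ccccn1)n2C1CCCCC1` gives >= 100000 nM
- Compound 2 `COc1ccc(-c2nc3cc(/C(C)=N/NC(N)=O)ccc3n2C2CCCCC2)cc1` gives "not determined" (no result reported)

For compound 2 the entry reads "not determined" (no result reported) and no number places it in the series. The only other entry belongs to compound 1, whose >= 100000 nM is a limit of the assay and not a number. Still to be measured is compound 3 `C/C(=N\NC(N)=O)c1ccc2c(c1)nc(-c1ccccn1)n2C1CCCCC1` and it has no result yet. The change pyridin-2-yl in place of 4-methoxyphenyl on an aromatic carbon is pyridin-2-yl in place of 4-methoxyphenyl on an aromatic carbon, between two ring nitrogen atoms. Going by the values given here, no measured step exists, so in this assay the expected step is none beyond the usual scatter, with no direction favoured. For compound 3 the estimated value is 70000 nM with an expected range from 20000 nM to 100000 nM on this read-out.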

Compound 3, half-maximal cytotoxic concentration: > 100000 nM
Compound 3: only a limit was reported; the forecaster's own chance of this, stated with the estimate: 55%; middle value at least 1.4-fold (0.15 log units) away from the limit.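

In this assay, going by these compounds alone, compound 1 and compound 3 both stand at a limit of the assay, so no step between them can be read. The compounds shown leave open whether pyridin-2-yl in place of 4-methoxyphenyl, or the exchange of the group on the aromatic carbon, shifts this read-out at all.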